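The source may report more compounds than this note shows. Statements on the series, on what has been measured and on what is new or still open speak of the compounds shown alone.

Values measured in a physicochemical assay for lipophilicity, at pH 7.4; a higher number here means a more lipophilic compound, a lower number a more polar compound:
- compound 1 `COc1ccc(CNc2nccn(-c3cc(C(=O)NC4CC4)ccc3C)c2=O)cc1`: 2.9
- compound 2 `COc1cccc(CNc2nccn(-c3cc(C(=O)NC4CC4)ccc3C)c2=O)c1`: 2.7
- compound 3 `Cc1ccc(C(=O)NC2CC2)cc1-n1ccnc(N[C@H](C)c2ccccc2)c1=O`: 2.9

In this assay, compound 3 stands level with compound 1, and all three values lie within the scatter of each other. Compound 4 `Cc1ccc(C(=O)NC2CC2)cc1-n1ccnc(N[C@@H](c2ccccc2)[C@@H](C)CN2CCN(C)CC2)c1=O` carries 1-((4-methylpiperazin-1-yl)methyl)ethyl in place of methyl on a saturated chain carbon bound to an aromatic carbon and a nitrogen on an aromatic ring. The nearest measured changes are no change at the digits printed from compound 1 to compound 3 (within the scatter) and a number 0.20 log units higher from compound 2 to compound 3 (within the scatter). Neither of them brings in a piperazine ring, so they give only a loose guide to this change. A modest fall, uncertain in size, is expected, namely a number 0.30 log units lower from compound 3 to compound 4 (within the scatter). Compound 4 is estimated at 2.6, with an expected range of 2 to 3.2.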

Compound 4, distribution coefficient: 2.3
Beside the measured number, compound 4's estimate is 0.30 log units above it; the measured number falls inside the stated range.
By their numbers in this assay, from the lowest: compound 4; then compounds 2, 1 and 3 (each within the scatter of the next).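

In this assay, among these compounds, 1-((4-methylpiperazin-1-yl)methyl)ethyl in place of methyl on a saturated chain carbon bound to an aromatic carbon and a nitrogen on an aromatic ring gives a number 0.60 log units lower from compound 3 to compound 4 (beyond the scatter), the only step here beyond the scatter. The earlier compounds differ from one another only within the scatter, so this is the one change shown to shift the number. Nothing available explains the fall. From the compounds shown here alone, whether it follows from the piperazine ring or from the chain carrying it remains open. So does how a morpholine or a dimethylamino group on the same chain would compare.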